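A few compounds are considered here, and "the series" means these few. Any claim that something is new, unique, unknown or untested is made for them only; others in the source may bear on it.

Measured compounds in an assay on isolated protein for binding affinity to ecdysone receptor (Lucilia cuprina), read by fluorescence polarization, with a stated time of 3 h; on this read-out higher numbers stand for weaker inhibition and lower numbers for stronger inhibition:
- compound 1, `C=C1C(C)=C(C#N)C(=O)N1c1c(C(C)C)cccc1C(C)C`: 23500 nM
- compound 2, `C=C1C(CC)=C(C#N)C(=O)N1c1cc(Cl)c(Cl)cc1Cl`: 7250 nM
- compound 3, `C=C1C(C(C)C)=C(C#N)C(=O)N1c1ccccc1C(C)(C)C`: 15000 nM

On these three numbers compound 3 stands second highest. Its nearest neighbour is compound 1, whose number is somewhat higher but within the usual scatter of this assay, so no order between compound 3 and compound 1 can be read from the data. Compound 2 gives the lowest number of the three, and its gap to compound 3 lies beyond the scatter.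

Compound 4, `C=C1C(C(C)C)=C(C#N)C(=O)N1c1ccc(Cl)cc1C(C)(C)C`, has not yet been measured in this assay. It differs from compound 3 in one place: chloro in place of hydrogen on an aromatic carbon. For the measured compounds named here, no pair of measured compounds shows the effect of adding a chloro group on its own, so the size of this step is not backed by a direct comparison. The only aryl ring in the series carrying chloro groups belongs to compound 2, whose value of 7250 nM is the lowest shown, which gives a weak hint toward a lower number rather than a higher one.

For compound 4 a small step downward from compound 3 is expected, of about a 1.7-fold lower number from compound 3 to compound 4 (0.22 log units; within the scatter), close to the edge of the scatter. The estimate for compound 4 in this assay is 9000 nM, with a range from 3000 nM to 27000 nM.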

Compound 4, half-maximal inhibitory concentration: 42000 nM
For compound 4 the middle estimate is 4.7-fold (0.67 log units) below the measured one, and the stated range ends below it.
By their numbers in this assay, from the lowest: compound 2; then compounds 3, 1 and 4 (each within the scatter of the next, the first and the last beyond it).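

In this assay chloro in place of hydrogen on an aromatic carbon, meta to a tert-butyl group and para to a large group, gives a 2.8-fold higher number from compound 3 to compound 4 (0.45 log units; beyond the scatter) and so moves toward weaker inhibition. For the compounds shown here, this is the first comparison that isolates a single change, and the step lies beyond the scatter, so this position is not indifferent to the change. The direction of the step holds only for this one pair of compounds, and no measurement shown accounts for it.

Whether the step belongs to chloro in particular or to any group at this carbon stays open, as the compounds shown carry no fluoro, methoxy or amine there. Also open, as far as these compounds go, is whether chloro would give a step of the same direction and size with a group other than tert-butyl on the ring.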